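This account rests on a few compounds, and the source may have more. Where it says the series, first, only, none or still open, it means among the compounds named here.

Working notes on the sulfonate ester series. In a functional assay on M21 cells (Homo sapiens) for antiproliferative activity, read by sulforhodamine B assay, with a stated time of 48 h (a higher number here means a weaker inhibitor, a lower number a stronger inhibitor), compound 2 `CCC(=O)Nc1ccc(S(=O)(=O)Oc2ccccc2C(C)C)cc1` gives 11000 nM. Compound 3 `CCC(=O)Nc1ccc(S(=O)(=O)Oc2ccccc2I)cc1` gives 11000 nM in this assay, and compound 1 `CCC(=O)Nc1cccc(S(=O)(=O)Oc2ccccc2C(C)C)c1` gives 25000 nM. Compound 2 thus stands level with compound 3, the two sharing the lowest number of the three, while the gap up to compound 1 lies beyond the scatter. Among the measured compounds shown here, the one single-place step among the measured compounds, no change at the digits printed from compound 2 to compound 3 (within the scatter), sits on the aromatic ring carrying the sulfonate ester and left the number unchanged within the scatter.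

The next compound, compound 4 `CC(C)C(=O)Nc1ccc(S(=O)(=O)Oc2ccccc2C(C)C)cc1`, differs from compound 2 by methyl in place of hydrogen on a saturated chain carbon bound to a carbonyl carbon and a saturated chain carbon. For the measured compounds named here, no measured step touches the acyl chain of the amide, so nothing among the known numbers speaks for or against a shift here; the only known step, from compound 2 to compound 3, stayed within the scatter on a different part of the molecule. The expectation for compound 4 is therefore no step beyond the scatter, no change at the digits printed from compound 2 to compound 4 (within the scatter). Compound 4 is estimated at 11000 nM, with a range from 5000 nM to 25000 nM.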

Compound 4, half-maximal inhibitory concentration: 11000 nM
Estimate against measurement, compound 4: no gap at the digits printed, within the range that was stated.
By their numbers in this assay, from the lowest: compounds 2, 3 and 4 (each within the scatter of the next); then compound 1.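

In this assay, among the compounds shown here, the step on the acyl chain of the amide, no change at the digits printed from compound 2 to compound 4 (within the scatter), gives the first reading at this place, and methyl in place of hydrogen on this saturated chain carbon, which turns propanoylamino into (isopropylcarbonyl)amino, brings no shift beyond the scatter. The other single-place step in the series, no change at the digits printed from compound 2 to compound 3 (within the scatter), lies on the ring carrying the sulfonate ester and also stays within the scatter, so neither of the two changes read so far moves the number beyond it. The data hold nothing that would account for this flat reading at the acyl chain.

As far as these compounds go, a single methyl says little about larger changes here, so it remains open how a longer chain such as hexanoyl, a phenyl ring or an amine on the acyl chain would read. From the compounds shown here alone, it also remains open whether the same methyl would read the same way on compound 1.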